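This account rests on a few compounds, and the source may have more. Where it says the series, first, only, none or still open, it means among the compounds named here.

Values so far in an ADME assay on liver (Mesocricetus auratus) for metabolic stability, using microsomes; a lower number here means slower removal, a higher number faster removal of the compound
- compound 1 `N#Cc1ccc(C2CCN(C(=O)Nc3cc(-c4ccccn4)n[nH]3)CC2)cc1` gives 80.8 mL.min-1.g-1
- compound 2 `O=C(Nc1cc(-c2ccccn2)n[nH]1)N1CCC(c2ccc(F)cc2)CC1` gives 272 mL.min-1.g-1
- compound 3 `O=C(Nc1cc(-c2ccccn2)n[nH]1)N1CCC(c2ccc(Cl)cc2)CC1` gives 43.8 mL.min-1.g-1

Compound 3 has the lowest number of the three, though it cannot be separated from compound 1, with a 1.8-fold lower number from compound 1 to compound 3 (0.27 log units; within the scatter). Compound 2 stands clearly apart, with a 6.2-fold lower number from compound 2 to compound 3 (0.79 log units; beyond the scatter).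

The next compound is compound 4 `O=C(Nc1cc(-c2ccccn2)n[nH]1)N1CCC(c2ccccc2)CC1`, which has the same structure as compound 3 except for one group. The change is hydrogen in place of chloro on an aromatic carbon, so 4-chlorophenyl becomes phenyl.

For the measured compounds named here, no measured compound has hydrogen at this position, so the evidence is indirect. The three measured compounds differ only in the group at this same position, and those swaps can matter: besides the step above, there is a 3.4-fold higher number from compound 1 to compound 2 (0.53 log units; beyond the scatter). Swaps here can also leave the number within the scatter, as compound 1 and compound 3 show. Since compound 3 already has the lowest number, a rise seems more likely than a further fall, but probably a smaller one than the gap to compound 2. The expected step is a 3.0-fold higher number from compound 3 to compound 4 (0.47 log units; beyond the scatter), a modest rise in this assay. For compound 4 the estimate is 130 mL.min-1.g-1, with an expected range from 50 mL.min-1.g-1 to 300 mL.min-1.g-1.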

Compound 4, intrinsic clearance in microsomes: 216 mL.min-1.g-1
Estimate against measurement, compound 4: 1.7-fold (0.22 log units) below; the range from low to high includes it.
By their numbers in this assay, from the lowest: compounds 3 and 1 (each within the scatter of the next); then compounds 4 and 2 (each within the scatter of the next).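

In this assay, the phenyl ring with only hydrogen at this position gives the series its unsubstituted reference point, and taking away the chloro group costs compound 3 its low number (a 4.9-fold higher number from compound 3 to compound 4 (0.69 log units; beyond the scatter)). Against that reference, fluoro makes no difference that can be told from the scatter (a 1.3-fold lower number from compound 2 to compound 4 (0.10 log units; within the scatter)), while the nitrile does go with a lower number than hydrogen (a 2.7-fold higher number from compound 1 to compound 4 (0.43 log units; beyond the scatter)), so chloro and cyano lower the number here and fluoro does not, and the four compounds fall into two groups, with compounds 1 and 3 in one and compounds 2 and 4 in the other. Nothing measured here explains why fluoro behaves like hydrogen while chloro and cyano do not.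

The compounds shown leave open whether other groups at this position, such as bromo, methyl, methoxy or trifluoromethyl, would join chloro and cyano or stay with fluoro and hydrogen. On these data alone, all four compounds also share one core, so whether these steps would hold if another part of the molecule changed remains unknown.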